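Two Fluorines Change Places and Cytotoxicity Stays Unreadable

The source may report more compounds than this note shows. Statements on the series, on what has been measured and on what is new or still open speak of the compounds shown alone.

Three close relatives share one core and differ only in where two fluorine atoms sit on a phenyl ring attached to an aromatic nitrogen. Compound 1 `Cc1ccccc1-c1nn(-c2cc(F)ccc2F)cc1CNCCN1CCN(C)CC1` carries a 2,5-difluorophenyl there. In an ADME assay on Huh-7 cells (Homo sapiens) for cytotoxicity (on this read-out lower numbers stand for higher toxicity in this test and higher numbers for lower toxicity in this test), compound 1 gives > 20000 nM, which is a limit of the test rather than a number. Compound 2 `Cc1ccccc1-c1nn(-c2ccc(F)c(F)c2)cc1CNCCN1CCN(C)CC1` carries a 3,4-difluorophenyl instead. In this assay compound 2 gives > 20000 nM, again a limit and not a number. Both results thus rest at the same boundary (the limit of > 20000 nM in this assay, at which 2 of the 2 values shown sit), and the step that the two limits leave unreadable from compound 1 to compound 2 cannot be read in size or direction. Compound 3 `Cc1ccccc1-c1nn(-c2ccc(F)cc2F)cc1CNCCN1CCN(C)CC1` is the next relative: 2,4-difluorophenyl in place of 3,4-difluorophenyl on an aromatic nitrogen. Going by the values given here, no measured step shows how moving fluorines within this ring shifts the read-out, since the one step available is hidden by two limits. Among the compounds with values here, the only guide is that neither neighbour reached a readable toxicity. Compound 3 is expected to rest near the same boundary, and the step that the limit leaves unreadable from compound 2 to compound 3 is expected to stay within the scatter. The estimate for compound 3 is 30000 nM, with a range from 15000 nM to 80000 nM.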

Compound 3, half-maximal cytotoxic concentration: > 20000 nM
Compound 3 gave a limit, no number; the forecaster's own chance of this, stated with the estimate: 80%; the middle value lies beyond the limit too.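

Going by these compounds alone, no step among compound 1, compound 2 and compound 3 can be read in size or direction in this assay because each result is a limit and not a number: the limit of > 20000 nM in this assay, at which 3 of the 3 values shown sit.

The compounds shown leave open whether moving the two fluorines around the phenyl ring changes cytotoxicity at all, and at what concentration any of the three would harm these cells.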